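A few compounds are considered here, and "the series" means these few. Any claim that something is new, unique, unknown or untested is made for them only; others in the source may bear on it.

Measured compounds:
compound 1 `COc1cc(-c2cc(C(=O)/C=C/c3ccc(Cl)cc3)nc3cc(-c4ccccc4)nn23)cc(OC)c1OC` gives 23800 nM
compound 2 `COc1cc(-c2cc(C(=O)/C=C/c3ccccc3)nc3cc(-c4ccccc4)nn23)cc(OC)c1OC` gives 18000 nM
compound 3 `COc1ccc(-c2cc(C(=O)/C=C/c3cc(OC)c(OC)c(OC)c3)nc3cc(-c4ccccc4)nn23)cc1OC` gives 15400 nM

These three values come from a functional assay on A549 cells (Homo sapiens) for antiproliferative activity, read by MTT assay, with a stated time of 24 h; on this read-out higher numbers stand for weaker inhibition and lower numbers for stronger inhibition. Compound 3 has the lowest of the three numbers, but its gap to compound 2 and to compound 1 lies within the scatter of repeated measurements, so no ordering among the three can be claimed.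

Compound 4 `COc1cc(/C=C/C(=O)c2cc(-c3cc(OC)c(OC)c(OC)c3)n3nc(-c4ccccc4)cc3n2)cc(OC)c1OC` has not yet been measured. It differs from compound 3 in one place: methoxy in place of hydrogen on an aromatic carbon. Cut one bond further out, this reads as 3,4-dimethoxyphenyl becoming 3,4,5-trimethoxyphenyl on the aryl group attached to the shared core.

For the measured compounds named here, only one measured step is available, and it sits on a different ring: a 1.3-fold lower number from compound 1 to compound 2 (0.12 log units; within the scatter). That change is small and lies within the scatter, which suggests single-substituent changes on these aryl rings move this assay little. Nothing measured addresses a methoxy added to the core-attached aryl directly.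

Compound 4 is therefore expected to stay close to compound 3, with a step of a 1.1-fold lower number from compound 3 to compound 4 (0.04 log units; within the scatter) that does not clearly exceed the scatter. The estimate for compound 4 is 14000 nM, with a range from 6000 nM to 35000 nM.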

Compound 4, half-maximal inhibitory concentration: 25900 nM
The estimate for compound 4 lay 1.9-fold (0.27 log units) below the measured number; low and high end bracket the measured number.
By their numbers in this assay, from the lowest: compounds 3, 2, 1 and 4 (each within the scatter of the next).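

In this assay, the methoxy that turns 3,4-dimethoxyphenyl into 3,4,5-trimethoxyphenyl on the aryl group attached to the shared core gives a 1.7-fold higher number from compound 3 to compound 4 (0.23 log units; within the scatter) and so has no readable effect at this position, ortho to a methoxy group. On the double-bonded chain carbon, 3,4,5-trimethoxyphenyl in place of phenyl gives a 1.4-fold higher number from compound 2 to compound 4 (0.16 log units; within the scatter) and in place of 4-chlorophenyl gives a 1.1-fold higher number from compound 1 to compound 4 (0.04 log units; within the scatter), so this change at the other aryl position also has no readable effect. No outside data bear on why these numbers stay so close.

Going by these compounds, whether an amine or a carboxylic acid on the core-attached aryl group would move the number beyond the scatter remains open. So does the effect of a hydroxy group in place of the added methoxy.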